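This account rests on a few compounds, and the source may have more. Where it says the series, first, only, none or still open, it means among the compounds named here.

Of the compounds shown here, three built on one shared core have been measured so far in a functional assay on U-937 cells (Homo sapiens) for cytotoxicity, read by MTT assay, with a stated time of 24 h; a higher number here means a weaker inhibitor, a lower number a stronger inhibitor. Compound 1 `Nc1nn(Cc2cn(CCC(F)(F)C(F)(F)C(F)(F)C(F)(F)C(F)(F)C(F)(F)F)nn2)c2nc(-c3ccccc3)cc(C(F)(F)F)c12` gives 98.2 ug/mL, compound 2 `Nc1nn(Cc2cn(-c3ccc(F)c(Cl)c3)nn2)c2nc(-c3ccccc3)cc(C(F)(F)F)c12` gives 99.1 ug/mL, and compound 3 `Cc1c(Br)cccc1-n1cc(Cn2nc(N)c3c(C(F)(F)F)cc(-c4ccccc4)nc32)nn1` gives 97.2 ug/mL. These numbers all lie within the scatter of one another, so compound 3 stands level with the other two and no ranking can be read from them.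

The next compound, compound 4 `Nc1nn(Cc2cn(CC(=O)NC3CCCCC3)nn2)c2nc(-c3ccccc3)cc(C(F)(F)F)c12`, keeps the core and alters one group: (cyclohexylcarbamoyl)methyl in place of 3-bromo-2-methylphenyl on an aromatic nitrogen. In words, (cyclohexylcarbamoyl)methyl takes the place of 3-bromo-2-methylphenyl on an aromatic nitrogen.

Among the measured compounds shown here, the only measured step at this nitrogen is a 1.0-fold lower number from compound 2 to compound 3 (0.01 log units; within the scatter), which swaps one substituted phenyl for another. Compound 1, with a quite different group on the same nitrogen, also shows 98.2 ug/mL. The new group is unlike any tested so far, so this support is limited, but no change beyond the scatter is expected in this assay. The expected step is a 1.0-fold lower number from compound 3 to compound 4 (0.01 log units; within the scatter). For compound 4 the estimated value is 95 ug/mL, with an expected range from 65 ug/mL to 130 ug/mL.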

Compound 4, half-maximal inhibitory concentration: 89 ug/mL
The estimate for compound 4 lay 1.1-fold (0.03 log units) above the measured number, within the range that was stated.
By their numbers in this assay, from the lowest: compounds 4, 3, 1 and 2 (each within the scatter of the next).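

In this assay, the group on this aromatic nitrogen now spans a wider range of types, and (cyclohexylcarbamoyl)methyl gives a 1.1-fold lower number from compound 3 to compound 4 (0.04 log units; within the scatter) and a 1.1-fold lower number from compound 2 to compound 4 (0.05 log units; within the scatter) without leaving the scatter. The earlier compounds shown here carried no amide group here: compound 4 brings a six-membered non-aromatic ring, a hydrogen-bond donor and a hydrogen-bond acceptor in place of the aromatic ring of compound 3. Even so, its number stays level with those of compound 2 and compound 3, and nothing available explains this lack of change.

On these data alone, whether a simple amine, a carboxylic acid or a short methyl group on this nitrogen would stay level as well remains open. The compounds shown also leave open whether any change elsewhere on the shared core, such as replacing the trifluoromethyl group with a nitrile, would move the number beyond the scatter.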